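Working notes: compound 2 to compound 3

This account rests on a few compounds, and the source may have more. Where it says the series, first, only, none or still open, it means among the compounds named here.

Measured so far in an assay on isolated protein for inhibition of serine/threonine-protein kinase PAK 4 (Homo sapiens), read by filter binding, with a stated time of 20 min, tested at 2 uM; a lower number here means less inhibition, a higher number more inhibition at the concentration tested (going by the name of the read-out):
compound 1, `OCC(O)CNc1nc(Nc2ccccc2)nc2[nH]ccc12`, gives 82.4%
compound 2, `OCCNc1nc(Nc2ccccc2)nc2[nH]ccc12`, gives 86.9%

Compound 2 carries the higher of the two numbers, with compound 1 nearest: a number 4.5 percentage points higher from compound 1 to compound 2 (within the scatter). Compound 3, `c1ccc(Nc2nc(N3CCNCC3)c3cc[nH]c3n2)cc1`, differs from compound 2 in one place: piperazin-1-yl in place of (2-hydroxyethyl)amino on an aromatic carbon. Among the compounds with values here, no measured step touches this exchange; the only step known, a number 4.5 percentage points higher from compound 1 to compound 2 (within the scatter), concerns hydrogen in place of hydroxymethyl and is within the scatter. Accordingly nothing beyond the scatter is expected for compound 3, estimated as a number 6.9 percentage points lower from compound 2 to compound 3 (within the scatter). Compound 3 is expected near 80%, between 55% and 95%.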

Compound 3, a percentage reported as inhibition, at one concentration (the size of the read-out at that concentration, not a potency): 89.6%
Compound 3: middle estimate off by 9.6 percentage points, on the low side; the range from low to high includes it.
By their numbers in this assay, from the lowest: compounds 1, 2 and 3 (each within the scatter of the next).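

The position on the aromatic carbon opposite the ring nitrogen also accepts a ring: piperazin-1-yl, which carries no oxygen, replaces the open hydroxylated chains, giving a number 2.7 percentage points higher from compound 2 to compound 3 (within the scatter) and a number 7.2 percentage points higher from compound 1 to compound 3 (within the scatter) as the two steps. Open chain and ring are therefore not separated at this single concentration, and the earlier step covered only a chain variation. Nothing available bears on this result.

From the compounds shown here alone, whether a carboxylic acid or a longer chain on this carbon would give a step beyond the scatter remains open. So does the effect of a substituted piperazine nitrogen.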